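This account rests on a few compounds, and the source may have more. Where it says the series, first, only, none or still open, it means among the compounds named here.

Measured compounds:
compound 1 `CCOC(=O)c1ccc(Cl)cc1O[C@H]1CC[C@H]2CN[C@H](C(=O)OCC)C[C@H]2C1` gives 15700 nM in an ADME assay on the whole organism (strain Fischer) for pharmacokinetics, with Rattus norvegicus as the target, at a dose of 30 mg/kg by the oral route; on this read-out lower numbers stand for lower exposure and higher numbers for higher exposure at the dose given;
compound 2 `CCOC(=O)c1ccc(-c2ccccc2)cc1O[C@H]1CC[C@H]2CN[C@H](C(=O)OCC)C[C@H]2C1` gives 5970 nM in this assay.

Among the compounds with values here, compound 2 stands lowest of the two numbers, and its nearest neighbour is compound 1; the only step that joins them, a 2.6-fold lower number from compound 1 to compound 2 (0.42 log units; beyond the scatter), lies beyond the scatter. Compound 3 `CCOC(=O)c1ccccc1O[C@H]1CC[C@H]2CN[C@H](C(=O)OCC)C[C@H]2C1` has not been measured in this assay. It differs from compound 2 by hydrogen in place of phenyl on an aromatic carbon. Within the data shown here, the one step that bears on this change is a 2.6-fold lower number from compound 1 to compound 2 (0.42 log units; beyond the scatter), which runs in the opposite sense, from a chloro to a phenyl, and it was modest. Compound 3 carries neither group, so its number is expected to move back up from that of compound 2, toward the value of compound 1, by roughly the size of that step, expressed as a 2.0-fold higher number from compound 2 to compound 3 (0.30 log units; within the scatter). Compound 3 is therefore estimated to give 12000 nM in this assay, within a range from 5000 nM to 30000 nM.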

Compound 3, maximal plasma concentration: 24500 nM
Beside the measured number, compound 3's estimate is 2.0-fold (0.31 log units) below it; the range from low to high includes it.
By their numbers in this assay, from the lowest: compound 2; then compounds 1 and 3 (each within the scatter of the next).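

With hydrogen in place of phenyl on the aromatic carbon para to an ethoxycarbonyl group, this assay shows a 4.1-fold higher number from compound 2 to compound 3 (0.61 log units; beyond the scatter) and so places phenyl apart from hydrogen as well as from chloro. Hydrogen in place of chloro gives a 1.6-fold higher number from compound 1 to compound 3 (0.19 log units; within the scatter) and leaves these two groups indistinguishable on this read-out, so among these three compounds only the phenyl group marks a clear difference in this assay. Nothing available explains this difference.

The compounds shown leave open whether a methyl, a methoxy, an amine or a carboxylic acid on this carbon would fall with hydrogen and chloro or with phenyl. They also leave open whether phenyl on another carbon of this ring would give a step of the same direction.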